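A 4-methoxyphenyl group replaces 2-nitrophenyl

The source may report more compounds than this note shows. Statements on the series, on what has been measured and on what is new or still open speak of the compounds shown alone.

Compound 1 `N#Cc1ccc(/C=C/C(=O)Nc2cc3c(Nc4ccc(F)c(Cl)c4)ncnc3cc2O[C@H]2CCOC2)cc1` gives 36600 nM
Compound 2 `O=C(/C=C/c1ccccc1[N+](=O)[O-])Nc1cc2c(Nc3ccc(F)c(Cl)c3)ncnc2cc1O[C@H]1CCOC1` gives 7760 nM

Both numbers come from a functional assay on PC-3 cells (Homo sapiens) for cytotoxicity, read by MTT assay, with a stated time of 72 h (on this read-out lower numbers stand for stronger inhibition and higher numbers for weaker inhibition), and no others are at hand. Compound 2 holds the lower of the two. Within the data shown here, the only measured step is a 4.7-fold lower number from compound 1 to compound 2 (0.67 log units; beyond the scatter) and it brings 2-nitrophenyl in place of 4-cyanophenyl on a double-bonded chain carbon bound to a double-bonded chain carbon.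

Compound 3 `COc1ccc(/C=C/C(=O)Nc2cc3c(Nc4ccc(F)c(Cl)c4)ncnc3cc2O[C@H]2CCOC2)cc1` is not yet measured, and it changes that same place again: 4-methoxyphenyl in place of 2-nitrophenyl on a double-bonded chain carbon bound to a double-bonded chain carbon with 4-methoxyphenyl in place of 2-nitrophenyl. Two compounds set no trend, but that one step shows that a swap here can move the number beyond the scatter. Compound 2 already stands low at 7760 nM so a modest move toward a higher number seems the likelier outcome, though nothing measured fixes the direction. The expected step is a 2.1-fold higher number from compound 2 to compound 3 (0.31 log units; beyond the scatter) and it remains only an estimate. For compound 3 the estimate is 16000 nM within an expected range from 5000 nM to 50000 nM as its likely span.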

Compound 3, half-maximal inhibitory concentration: 2240 nM
Compound 3: middle estimate off by 7.1-fold (0.85 log units), on the high side; the whole stated range lies above it.
By their numbers in this assay, from the lowest: compound 3; then compound 2; then compound 1.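

In this assay, 4-methoxyphenyl in place of 2-nitrophenyl gives a 3.5-fold lower number from compound 2 to compound 3 (0.54 log units; beyond the scatter), so a second swap on the double-bonded chain carbon bound to a double-bonded chain carbon also moves the number beyond the scatter, and the earlier step proves not to be a lone case. Methoxy in place of cyano on an aromatic carbon gives a 16-fold lower number from compound 1 to compound 3 (1.21 log units; beyond the scatter), a large step that shows this place can change the number far more than the modest step from the first pair suggested, with the three aryl groups now ordered 4-methoxyphenyl, 2-nitrophenyl, 4-cyanophenyl from the lowest number to the highest. Nothing available bears on the reason for this order.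

The compounds shown leave open whether the order follows the identity of the substituent or where it sits on the ring, since 2-methoxyphenyl and 4-nitrophenyl would be needed to separate the two. They also leave open how an unsubstituted phenyl or a 4-aminophenyl would stand in this place, and whether a dimethylamino group could replace the aryl ring altogether.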